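Compound 3 to compound 4: a longer chain at the limit

A few compounds are considered here, and "the series" means these few. Any claim that something is new, unique, unknown or untested is made for them only; others in the source may bear on it.

Measured so far in an ADME assay on MT4 cells (Homo sapiens) for cytotoxicity, read by MTT assay, with a stated time of 5 days; a lower number here means that less compound is tolerated, a higher number that more compound is tolerated:

Compound 1 `CNc1cc(Oc2c(OC)cc3cc(C#N)ccc3c2OC)nc(Nc2ccc(C#N)cc2)n1` gives 239000 nM
Compound 2 `COc1cc2cc(C#N)ccc2c(OC)c1Oc1cc(NC(C)(C)C)nc(Nc2ccc(C#N)cc2)n1` gives > 125000 nM
Compound 3 `CCC(CC)Nc1cc(Oc2c(OC)cc3cc(C#N)ccc3c2OC)nc(Nc2ccc(C#N)cc2)n1` gives > 125000 nM

Only compound 1 has an exact number. Compound 2 stands at > 125000 nM as a limit and not a number. Compound 3 stands at > 125000 nM as a limit too. Compound 3 therefore rests on the limit of > 125000 nM in this assay, at which 2 of the 3 values shown sit, and has no exact place on the scale.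

The change to compound 4 `CCCCCC(C)Nc1cc(Oc2c(OC)cc3cc(C#N)ccc3c2OC)nc(Nc2ccc(C#N)cc2)n1` is 1-methylhexyl in place of pentan-3-yl on a nitrogen on an aromatic ring with 1-methylhexyl in place of pentan-3-yl on a nitrogen on an aromatic ring. Within the data shown here, the steps that bear on it, all made in that same place, are a step that the limit leaves unreadable from compound 1 to compound 2 and a step that the limit leaves unreadable from compound 1 to compound 3 and also a step that the two limits leave unreadable from compound 2 to compound 3 in the same series. None of the three has a readable size, so together they set no measure for this change.

No step beyond the usual scatter is expected in either direction, and a further limit is quite possible for compound 4. The expected change is an at least 1.0-fold lower number from compound 3 to compound 4 (0.01 log units; that floor lies within the scatter) as an estimate only. For compound 4 the expected value is 120000 nM with an estimated range from 40000 nM to 250000 nM in this assay here.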

Compound 4, half-maximal cytotoxic concentration: > 125000 nM
Compound 4: only a limit was reported; the forecaster's own chance of this, stated with the estimate: 60%; middle value at least 1.0-fold (0.01 log units) from the limit.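

Among these compounds, compound 4 gives > 125000 nM in this assay as a limit and not a number, so no step from compound 1, compound 2 or compound 3 to compound 4 can be read, and compound 4 joins the others on the same limit: the limit of > 125000 nM in this assay, at which 3 of the 4 values shown sit. In this assay the compounds shown leave open how far compound 2, compound 3 and compound 4 differ from one another or from compound 1.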